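The source may hold more compounds than are shown below. What is called first, only, known or untested is meant among the compounds shown, and "the series" means these compounds.

Measured compounds in an ADME assay on cells for inhibition of cytochrome P450 11B1, mitochondrial (Homo sapiens), read by HTRF; on this read-out lower numbers stand for stronger inhibition and higher numbers for weaker inhibition:
compound 1 `CC[C@H]1c2cc(Cl)ccc2C(=O)N1c1cncc2c1CCC[C@H]2NC(C)=O` gives 3630 nM
compound 2 `CC1CN(c2cccnc2)C(=O)c2ccc(Cl)cc21` gives 2590 nM
compound 3 `O=C1c2cc(F)c(Cl)cc2CCN1c1cccnc1` gives 3540 nM

Compound 1 stands as the highest of the three numbers, but the three values sit within the scatter of each other, so no ordering of compounds 1, 2 and 3 can be read from them. Compound 4 `CCC(=O)N[C@@H]1CCCc2c1cncc2N1C(=O)c2ccc(Cl)cc2[C@@H]1CC` has not yet been measured. It differs from compound 1 in one place: methyl in place of hydrogen on a saturated chain carbon bound to a carbonyl carbon. The acetamido of compound 1 becomes propanoylamino. Nothing in the measured set tests a step of this kind, so no direction is given by the data. The change is small and remote from the shared core, and the expected step from compound 1 to compound 4 in this assay is a 1.2-fold lower number from compound 1 to compound 4 (0.08 log units; within the scatter), within the scatter. Compound 4 is therefore estimated at 3000 nM, in a range from 1200 nM to 7500 nM.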

Compound 4, half-maximal inhibitory concentration: 345 nM
The estimate for compound 4 lay 8.7-fold (0.94 log units) above the measured number, outside the stated range (below it).
By their numbers in this assay, from the lowest: compound 4; then compounds 2, 3 and 1 (each within the scatter of the next).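

In this assay, the acetamido to propanoylamino change, methyl in place of hydrogen on a saturated chain carbon bound to a carbonyl carbon, gives an 11-fold lower number from compound 1 to compound 4 (1.02 log units; beyond the scatter) and is a large step. The earlier compounds shown here showed no step at all; this one shows that the number is highly sensitive to this chain, where one methyl is enough to move it beyond the scatter. Nothing at hand accounts for the size of this step.

Still open, on these data alone, is whether a longer chain, such as butanoyl, extends the step or reverses it. As far as these compounds go, an amine or a carboxylic acid on the same chain also remains untested here.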